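From difluorophenyl to pentafluorophenyl on the shared core

The source may report more compounds than this note shows. Statements on the series, on what has been measured and on what is new or still open speak of the compounds shown alone.

Measured in a functional assay on Jurkat cells (Homo sapiens); on this read-out lower numbers stand for stronger inhibition and higher numbers for weaker inhibition:
compound 1 `CC(C)[C@H](NC(=O)COc1cccc2ccccc12)C(=O)N[C@@H](CC(=O)O)C(=O)COc1ccc(F)cc1F`: 33200 nM
compound 2 `CC(C)[C@H](NC(=O)COc1cccc2ccccc12)C(=O)N[C@@H](CC(=O)O)C(=O)COc1cc(F)ccc1F`: > 100000 nM (a limit)
compound 3 `CC(C)[C@H](NC(=O)COc1cccc2ccccc12)C(=O)N[C@@H](CC(=O)O)C(=O)COc1ccc(F)c(F)c1`: > 100000 nM (a limit)

Compound 3 stands at > 100000 nM, which is a limit and not a number. Compound 4 `CC(C)[C@H](NC(=O)COc1cccc2ccccc12)C(=O)N[C@@H](CC(=O)O)C(=O)COc1c(F)c(F)c(F)c(F)c1F` differs from it in one place, on an oxygen on a saturated carbon: 2,3,4,5,6-pentafluorophenyl in place of 3,4-difluorophenyl on an oxygen on a saturated carbon. Going by the values given here, two measured steps bear on this change: an at least 3.0-fold higher number from compound 1 to compound 2 (0.47 log units; beyond the scatter) and an at least 3.0-fold higher number from compound 1 to compound 3 (0.47 log units; beyond the scatter). Both leave the 2,4-difluorophenyl of compound 1, and the name 2,3,4,5,6-pentafluorophenyl still includes both of the numbers in that group's name. A modest move toward stronger inhibition is therefore expected, although a second limit remains possible. The step expected in this assay is an at least 2.5-fold lower number from compound 3 to compound 4 (0.39 log units; beyond the scatter). Compound 4 is estimated at 40000 nM, with an expected range of 8000 nM to 100000 nM.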

Compound 4, half-maximal inhibitory concentration: 3050 nM
Compound 4: middle estimate off by 13-fold (1.12 log units), on the high side; the whole stated range lies above it.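

In this assay, going by these compounds alone, the change to 2,3,4,5,6-pentafluorophenyl on this oxygen gives the first clear gain in this set, where the earlier steps only weakened inhibition: an 11-fold lower number from compound 1 to compound 4 (1.04 log units; beyond the scatter). Against the other two difluorophenyl compounds, the steps are an at least 32-fold lower number from compound 3 to compound 4 (1.51 log units; beyond the scatter) and an at least 32-fold lower number from compound 2 to compound 4 (1.51 log units; beyond the scatter). The values of compound 2 and compound 3 are limits and not numbers, and these two steps give only a minimum size: the limit of > 100000 nM in this assay, at which 2 of the 4 values shown sit.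

The compounds shown do not tell why the pentafluorophenyl group gives this gain. They also leave open how phenyl without fluorine or pentachlorophenyl would compare in this place on the shared core.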